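The compounds below may be only part of what the source reports. "The series", "measured", "known", "first", "only" and "open" are said of these compounds alone.

Of the compounds shown here, three here share a core and have been measured in a physicochemical assay for solubility, read by turbidimetry, measured as kinetic solubility, at pH 7.4; on this read-out higher numbers stand for higher solubility and lower numbers for lower solubility. Compound 1 `O=C(NCCCCn1cccn1)c1cccc(C2SCC(=O)N2c2ccccn2)c1` gives 50000 nM, the highest of the three numbers. Compound 2 `O=C(NCCCCc1ccccc1)c1cccc(C2SCC(=O)N2c2ccccn2)c1` gives 20000 nM, and compound 3 `COc1ccccc1N1C(=O)CSC1c1cc(F)cc(C(=O)NCCCCc2ccccc2)c1` gives 10000 nM. Among the compounds with values here, the one single-site step measured so far, a 2.5-fold lower number from compound 1 to compound 2 (0.40 log units; beyond the scatter), changes the chain end rather than the pyridine ring, so it does not speak directly to the change at hand. Compound 4 `O=C(NCCCCn1cccn1)c1cccc(C2SCC(=O)N2c2cc(F)ccn2)c1` differs from compound 1 by fluoro in place of hydrogen on an aromatic carbon. Within the data shown here, no measured pair here isolates this change, and compound 3 combines a fluorine with other alterations, so its value alone cannot be attributed. The step of a 1.3-fold lower number from compound 1 to compound 4 (0.10 log units; within the scatter) is therefore expected to stay within the scatter. Compound 4 is estimated at 40000 nM, in a range from 20000 nM to 80000 nM.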

Compound 4, solubility: 50000 nM
Compound 4: middle estimate off by 1.3-fold (0.10 log units), on the low side; the range from low to high includes it.
By their numbers in this assay, from the lowest: compounds 3 and 2 (each within the scatter of the next); then compounds 1 and 4 (each within the scatter of the next).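

In this assay, going from pyridin-2-yl to 4-fluoropyridin-2-yl gives no change at the digits printed from compound 1 to compound 4 (within the scatter) on this chain-end series. Within the data shown here, this is the first reading of fluoro alone at this position, opposite the ring nitrogen, since the fluorine in compound 3 came with other alterations. No measurement available here offers an explanation for this result.

As far as these compounds go, whether an amine or a carboxylic acid at this position would shift the number remains open. So does whether fluoro here would read the same with the phenyl chain end of compound 2.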